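The source may report more compounds than this note shows. Statements on the series, on what has been measured and on what is new or still open speak of the compounds shown alone.

Compound 1 `Cc1cccc(N(C)c2cc(Nc3cccc(C(=O)N(CC(C)C)CC(C)C)c3)ncn2)c1` gives 0% in an assay on isolated protein for inhibition of MAP kinase-activated protein kinase 2 (Homo sapiens), read by HTRF, tested at 10 uM (on this read-out lower numbers stand for less inhibition and higher numbers for more inhibition at the one concentration tested (going by the name of the read-out)), one of two numbers recorded so far; compound 2 `Cc1cccc(Oc2ccnc(N3CCC[C@H]3C(=O)NCCCn3ccnc3)n2)c1` gives 2% in this assay, a result within the scatter of that of compound 1. Compound 3 `Cc1cccc(N(C)c2cc(Nc3cccc(C(=O)N4CCCC5CCCCC54)c3)ncn2)c1` differs from compound 1 by a group of 10 heavy atoms (9 carbon, 1 nitrogen; one six-membered non-aromatic ring of carbon only, one six-membered non-aromatic ring with 1 hetero atom) in place of a group of 9 heavy atoms (8 carbon, 1 nitrogen; no ring), on a carbonyl carbon. Going by the values given here, no measured pair tests a change of this kind, so nothing points to a step beyond the scatter in either direction; with both known compounds near zero, the expected step is a number 2 percentage points higher from compound 1 to compound 3 (within the scatter), essentially none. Compound 3 is therefore estimated at 2%, in the range -8% to 12%.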

Compound 3, a percentage reported as inhibition, at one concentration (the size of the read-out at that concentration, not a potency): 0%
Beside the measured number, compound 3's estimate is 2 percentage points above it; low and high end bracket the measured number.
By their numbers in this assay, from the lowest: compounds 1, 3 and 2 (each within the scatter of the next).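

Working on the carbonyl carbon, the group with two six-membered non-aromatic rings in place of diisobutylamino gives no change at the digits printed from compound 1 to compound 3 (within the scatter) in this assay. Going by these compounds alone, this is the first pair to test this position, and closing the open-chain amine substituent into rings does not lift the read-out away from near zero. No supporting data bear on this result.

With both values near zero, the result does not show whether this position can affect inhibition at all. A dimethylamino group or a piperidine bearing a carboxylic acid on this carbonyl carbon remains an open test.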